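A few compounds are considered here, and "the series" means these few. Any claim that something is new, unique, unknown or untested is made for them only; others in the source may bear on it.

Measured compounds:
Compound 1 `C[C@H](NC(=O)c1ccc(-c2ccc(N)nc2)cc1)C(=O)Nc1ccc(Cl)c(C(F)(F)F)c1` gives 5950 nM in a functional assay on K562 cells (Homo sapiens) for inhibition, read by MTT assay, with a stated time of 48 h; on this read-out lower numbers stand for stronger inhibition and higher numbers for weaker inhibition.
Compound 2 `C[C@H](NC(=O)c1cccc(-c2ccc(NS(C)(=O)=O)nc2)c1)C(=O)Nc1ccc(Cl)c(C(F)(F)F)c1` gives 4660 nM.
Compound 3 `CC(=O)Nc1ccc(-c2ccc(C(=O)N[C@@H](C)C(=O)Nc3ccc(Cl)c(C(F)(F)F)c3)cc2)cn1` gives 107000 nM.

Compound 2 has the lowest number of the three, though its gap to compound 1 is within the scatter, so the two cannot be ranked; only compound 3 stands clearly apart. Compound 4 `C[C@H](NC(=O)c1cccc(-c2cncc(C(=O)NC3CC3)c2)c1)C(=O)Nc1ccc(Cl)c(C(F)(F)F)c1` is not yet measured. It differs from compound 2 in one place, on an aromatic carbon of a six-membered aromatic ring of carbon only, meta to a large group: 5-(cyclopropylcarbamoyl)pyridin-3-yl in place of 6-(methanesulfonamido)pyridin-3-yl on an aromatic carbon.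

Going by the values given here, one measured step bears on this part of the shared core, an 18-fold higher number from compound 1 to compound 3 (1.25 log units; beyond the scatter), in which acetyl replaced hydrogen on a nitrogen on an aromatic ring. Among the compounds with values here, it shows that changing this end of the molecule can move the number by a large amount, yet it is a different change, and no measured pair matches the present one. The expectation for compound 4 is therefore uncertain; a step toward a higher number, a 1.9-fold higher number from compound 2 to compound 4 (0.29 log units; within the scatter), is expected, with a wide range.

Compound 4 is estimated at 9000 nM, between 2500 nM and 35000 nM.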

Compound 4, half-maximal inhibitory concentration: 15100 nM
For compound 4 the middle estimate is 1.7-fold (0.22 log units) below the measured one; low and high end bracket the measured number.
By their numbers in this assay, from the lowest: compounds 2 and 1 (each within the scatter of the next); then compound 4; then compound 3.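

In this assay, going by these compounds alone, putting 5-(cyclopropylcarbamoyl)pyridin-3-yl in place of 6-(methanesulfonamido)pyridin-3-yl gives a 3.2-fold higher number from compound 2 to compound 4 (0.51 log units; beyond the scatter) and is the first measured exchange of the whole pyridine-bearing group at this aromatic carbon. It shows that the choice of group here changes the number by more than the usual scatter, though only modestly, far less than the large step seen earlier from a single acetyl on the nitrogen. No measurement shown here explains this step.

The exchange alters both the kind of side group and its place on the pyridine, so the compounds shown cannot say which of the two accounts for the step. Also open, on these data alone, is how a 6-(cyclopropylcarbamoyl)pyridin-3-yl group, or a carboxylic acid on the pyridine in place of the amide, would read in this assay at this position.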